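The source may hold more compounds than are shown below. What is called first, only, known or untested is meant among the compounds shown, and "the series" means these compounds.

Measured so far:
Compound 1, `CC(C)(C)c1ccc(-n2nnnc2SCC(=O)Nc2ccc(-c3ccc(OCC(=O)O)cc3)cc2Cl)c(Cl)c1`, gives 0.117 h.
Compound 2, `CC(C)(C)c1ccc(-n2nnnc2SCC(=O)Nc2ccc(-c3ccc(CC(=O)O)cc3)cc2Cl)c(Cl)c1`, gives 0.383 h.
Compound 3, `CCN(C(=O)CCC(=O)Nc1ccc(-c2ccc(OCC(=O)O)cc2)cc1Cl)c1ccc(C(C)(C)C)cc1Cl`, gives 0.1 h.

These three values come from an in vitro ADME assay on microsomes from liver (Homo sapiens) for metabolic stability; a lower number here means that the compound disappears faster, a higher number that the compound lasts longer. Compound 1 and compound 2 share one core and differ in a single spot: carboxymethyl in place of carboxymethoxy on an aromatic carbon. That change produced a 3.3-fold higher number from compound 1 to compound 2 (0.52 log units; beyond the scatter), a step reported as beyond the usual scatter of repeated measurements.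

Compound 4, `CCN(C(=O)CCC(=O)Nc1ccc(-c2ccc(CC(=O)O)cc2)cc1Cl)c1ccc(C(C)(C)C)cc1Cl`, has not yet been measured in this assay. It is built on the core of compound 3, and the difference between the core of compound 1 and the core of compound 3 is not broken down here. Compound 4 differs from compound 3 in exactly one spot: carboxymethyl in place of carboxymethoxy on an aromatic carbon. Going by the values given here, this is the same change as the one from compound 1 to compound 2, made at the same kind of place.

Because the earlier change gave a 3.3-fold higher number from compound 1 to compound 2 (0.52 log units; beyond the scatter), the step from compound 3 to compound 4 is expected to be of about the same size, around a 3.0-fold higher number from compound 3 to compound 4 (0.48 log units; beyond the scatter). Compound 4 is therefore estimated to give 0.3 h in this assay, with the likely range running from 0.15 h to 0.6 h.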

Compound 4, half-life: 0.05 h
For compound 4 the middle estimate is 6.0-fold (0.78 log units) above the measured one; the whole stated range lies above it.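

The new step in this assay is a 2.0-fold lower number from compound 3 to compound 4 (0.30 log units; within the scatter) and so, on this core, swapping carboxymethoxy for carboxymethyl gives a difference that repeat measurements alone could produce. Set beside the earlier step, the same change did not carry over from one core to the other: the same change on two cores in this assay, a 3.3-fold higher number (0.52 log units; beyond the scatter) from compound 1 to compound 2 and a 2.0-fold lower number (0.30 log units; within the scatter) from compound 3 to compound 4, 6.5-fold (0.82 log units) apart, beyond the scatter of two such steps. This shows that the step seen on the core of compound 1 is no reliable guide to the core of compound 3, but with a single pair on each core it does not show why the two differ or which part of the cores matters.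

From the compounds shown here alone, only carboxymethoxy and carboxymethyl appear at this place, so it remains open whether a longer chain ending in a carboxylic acid, or a primary amide in place of the acid, would behave alike on both cores. Also open, going by these compounds, is how the change would behave on a core that carries a methyl in place of the ethyl of compound 3.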